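Ring-amine substituent change in a two-point series

The compounds below may be only part of what the source reports. "The series", "measured", "known", "first", "only" and "open" are said of these compounds alone.

Measured in an assay on HEK293 cells for agonist activity at Toll-like receptor 8 (Homo sapiens), read by a luciferase reporter, with a stated time of 6 h; on this read-out higher numbers stand for an effect only at larger amounts of compound and lower numbers for an effect already at smaller amounts:
compound 1, `CCCCNc1nc(N)nc2c1CN(C)CC2`, gives 0.03 uM
compound 2, `CCCCNc1nc(N)nc2c1CN(Cc1cccc(Cl)c1Cl)CC2`, gives 0.18 uM

For the measured compounds named here, compound 1 holds the lowest of the two numbers; its only neighbour is compound 2, reached by a 6.0-fold higher number from compound 1 to compound 2 (0.78 log units; beyond the scatter), a modest rise that sits beyond the scatter.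

Compound 3, `CCCCNc1nc(N)nc2c1CN(C(=O)C1CCC1)CC2`, carries the change (cyclobutylcarbonyl in place of methyl on an amine nitrogen in a ring). Going by the values given here, the one measured step that bears on it is the change at the same amine nitrogen in a ring from compound 1 to compound 2, which moved the read-out upward by a modest amount. Among the compounds with values here, no measured compound carries a carbonyl on that nitrogen, so the size of the step for compound 3 rests on that single precedent alone. A rise of roughly comparable size is expected, a 10-fold higher number from compound 1 to compound 3 (1.00 log units; beyond the scatter). Compound 3 is therefore estimated at 0.3 uM, within a range of 0.06 uM to 1.5 uM.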

Compound 3, minimum effective concentration: 0.4 uM
The estimate for compound 3 lay 1.3-fold (0.12 log units) below the measured number; low and high end bracket the measured number.
By their numbers in this assay, from the lowest: compound 1; then compound 2; then compound 3.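

In this assay, for the compounds shown here, cyclobutylcarbonyl in place of methyl on the amine nitrogen in a ring gives a 13-fold higher number from compound 1 to compound 3 (1.12 log units; beyond the scatter), and this is the first carbonyl-bearing group seen at this position. Together with a 6.0-fold higher number from compound 1 to compound 2 (0.78 log units; beyond the scatter), it means that both replacements shown for the methyl of compound 1 raise the number, and no compound shown goes against this, so compound 1 keeps the lowest value of the three. Nothing available gives a reason for either rise.

As far as these compounds go, it remains open whether the rise for compound 3 goes with the carbonyl or with the four-membered ring, a question that acetyl or cyclobutylmethyl on the same nitrogen would help separate. Also open, from the compounds shown here alone, is how a plain hydrogen on that nitrogen would compare with methyl.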